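Working notes: from compound 3 to compound 4

The source may hold more compounds than are shown below. What is called first, only, known or untested is meant among the compounds shown, and "the series" means these compounds.

- compound 1 `N#Cc1ccc(N2CCc3cc(-c4cnc5ccccc5c4)ccc32)cc1C(F)(F)F` – "not determined" (no result reported)
- compound 2 `N#Cc1ccc(N2CCc3cc(-c4cncnc4)ccc32)cc1C(F)(F)F` – "not determined" (no result reported)
- compound 3 `CCN(c1ccc(C#N)c(Cl)c1)c1cc(-n2cnc3ccccc32)ccc1C` – 3040 nM

These entries come from a functional assay on CWR22R cells (Homo sapiens) for antiproliferative activity, read by CCK-8 assay, with a stated time of 6 days; on this read-out lower numbers stand for stronger inhibition and higher numbers for weaker inhibition. Of the three, only compound 3 has a number, so its position relative to compound 1 and compound 2 cannot be judged. The next entry is compound 4 `CCN(c1ccc(C#N)c(Cl)c1)c1cc(-c2ccccc2)ccc1C`, not yet measured, which carries phenyl in place of 1H-benzimidazol-1-yl on an aromatic carbon. Within the data shown here, no measured pair calibrates this change, and the only anchor is compound 3 at 3040 nM. The expected step is a 1.6-fold higher number from compound 3 to compound 4 (0.22 log units; within the scatter), a modest move toward weaker inhibition in this assay that may not clear the usual scatter. For compound 4 the estimated value is 5000 nM, with an expected range of 1500 nM to 15000 nM.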

Compound 4, half-maximal inhibitory concentration: > 30000 nM
Compound 4 ended at the assay's limit (the forecaster's own chance of this, stated with the estimate: 15%); middle value at least 6.0-fold (0.77 log units) from the limit.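

In this assay, the aromatic carbon para to a methyl group proves sensitive to the identity of its ring substituent: phenyl in place of 1H-benzimidazol-1-yl gives an at least 9.8-fold higher number from compound 3 to compound 4 (0.99 log units; beyond the scatter). Compound 4 stands at a limit of the assay, so this step is a lower bound: the limit of > 30000 nM in this assay, at which 1 of the 4 values shown sits.

This single pair changes ring size, ring nitrogens and hydrogen-bond acceptors together, so it cannot separate their contributions. Going by these compounds, whether a pyridin-3-yl, an imidazol-1-yl or a phenyl carrying an amine at this position would restore a measurable value remains open.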